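Nitro to Hydroxy Exchange in Two Related Series

The compounds below may be only part of what the source reports. "The series", "measured", "known", "first", "only" and "open" are said of these compounds alone.

The compounds measured so far in a functional assay on A549 cells (Homo sapiens) for cytotoxicity, read by MTT assay, with a stated time of 6 days; on this read-out higher numbers stand for an effect only at larger amounts of compound and lower numbers for an effect already at smaller amounts:
compound 1, `COC(=O)c1c(-c2ccc([N+](=O)[O-])cc2)oc2cc(OC)ccc2c1=O`, gives a limit of the assay, > 25 ug/mL.
compound 2, `COC(=O)c1c(-c2ccc(O)cc2)oc2cc(OC)ccc2c1=O`, gives a limit of the assay, > 25 ug/mL.
compound 3, `COc1ccc2oc(-c3ccc([N+](=O)[O-])cc3)c(C(=O)O)c(=O)c2c1`, gives a limit of the assay, > 25 ug/mL.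

Compound 1 and compound 2 differ in one place: hydroxy in place of nitro on an aromatic carbon. The step between them, a step that the two limits leave unreadable from compound 1 to compound 2, has no readable size, since both values are limits. All three values sit at the limit of > 25 ug/mL in this assay, at which 3 of the 3 values shown sit, so no ordering among compound 1, compound 2 and compound 3 can be drawn from this assay.

Compound 4, `COc1ccc2oc(-c3ccc(O)cc3)c(C(=O)O)c(=O)c2c1`, has not yet been measured in this assay. For the measured compounds named here, it differs from compound 3 by hydroxy in place of nitro on an aromatic carbon, which is the same change as the one between compound 1 and compound 2, made at the same kind of place. The cores of compound 1 and compound 3 differ, but the difference between the two cores is not broken down here.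

For compound 4 the expectation rests on (the limit of > 25 ug/mL in this assay, at which 3 of the 3 values shown sit), where compound 3 sits, and on the unreadable size of a step that the two limits leave unreadable from compound 1 to compound 2, which gives no sign that the exchange moves the value off that limit. The step expected from compound 3 to compound 4 in this assay is a step that the limit leaves unreadable from compound 3 to compound 4. Compound 4 is therefore estimated at 40 ug/mL, with a range from 15 ug/mL to 120 ug/mL, and it is expected that the assay will again report only a limit.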

Compound 4, concentration for half-maximal effect: > 25 ug/mL
Compound 4: a limit, no number; the forecaster's own chance of this, stated with the estimate: 85%; the middle value lies beyond the limit too.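

In this assay compound 4 gives > 25 ug/mL, which is a limit of the assay and not a number. For the compounds shown here, no step from compound 3 to compound 4 can therefore be read, and compound 4 joins the other compounds at the same value: the limit of > 25 ug/mL in this assay, at which 4 of the 4 values shown sit. The compounds shown leave open how large the exchange of nitro for hydroxy is in this assay on either core.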